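Fluoro step carried over to the second core

The source may hold more compounds than are shown below. What is called first, only, known or untested is meant among the compounds shown, and "the series" means these compounds.

Compound 1 `O=C(Nc1ccc(Oc2ccc(-c3nccs3)cc2)cc1)Nc1cccc(C(F)(F)F)c1` and compound 2 `O=C(Nc1ccc(Oc2ccc(-c3nccs3)cc2)cc1)Nc1ccc(F)c(C(F)(F)F)c1` share one core; compound 2 differs by fluoro in place of hydrogen on an aromatic carbon. In a functional assay on A549 cells (Homo sapiens) for inhibition, read by MTT assay and WST assay, with a stated time of 72 h, tested at 10 uM (on this read-out higher numbers stand for more inhibition of growth at the one concentration tested and lower numbers for less inhibition of growth), compound 1 gives 71.5%, and compound 2 gives 76.4%, a step of a number 4.9 percentage points higher from compound 1 to compound 2 (within the scatter). Compound 3 `O=C(Nc1ccc(Oc2ccc(-c3ncc[nH]3)cc2)cc1)Nc1cccc(C(F)(F)F)c1` carries the other core, differing from compound 1 by 1H-imidazol-2-yl in place of 1,3-thiazol-2-yl on an aromatic carbon; in this assay compound 3 gives 30%, a step of a number 41.5 percentage points lower from compound 1 to compound 3 (beyond the scatter), the lowest of the three numbers. Compound 4 `O=C(Nc1ccc(Oc2ccc(-c3ncc[nH]3)cc2)cc1)Nc1ccc(F)c(C(F)(F)F)c1` differs from compound 3 by fluoro in place of hydrogen on an aromatic carbon, the same change at the same place as between compound 1 and compound 2, now on the core of compound 3. Going by the values given here, a small expected step, a number 5 percentage points higher from compound 3 to compound 4 (within the scatter), rests on the one earlier pair, because a number 4.9 percentage points higher from compound 1 to compound 2 (within the scatter) stayed within the scatter; whether the core of compound 3 behaves alike is untested. The estimate for compound 4 in this assay is 35%, between 20% and 50%.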

Compound 4, percent growth inhibition at one concentration: 63.3%
Beside the measured number, compound 4's estimate is 28.3 percentage points below it; measured number above the stated range.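

On the core of compound 3, 4-fluoro-3-(trifluoromethyl)phenyl in place of 3-(trifluoromethyl)phenyl gives a number 33.3 percentage points higher from compound 3 to compound 4 (beyond the scatter), so in this assay the size of the fluoro step does not carry over from one core to the other: the same change on two cores in this assay, a number 4.9 percentage points higher (within the scatter) from compound 1 to compound 2 and a number 33.3 percentage points higher (beyond the scatter) from compound 3 to compound 4, 28.4 percentage points apart, beyond the scatter of two such steps

Seen from the other side, 1H-imidazol-2-yl in place of 1,3-thiazol-2-yl gives a number 13.1 percentage points lower from compound 2 to compound 4 (beyond the scatter) when the fluoro is present, so the two changes do not simply add: the same change on two cores in this assay, a number 41.5 percentage points lower (beyond the scatter) from compound 1 to compound 3 and a number 13.1 percentage points lower (beyond the scatter) from compound 2 to compound 4, 28.4 percentage points apart, beyond the scatter of two such steps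

This rests on four compounds at a single concentration, and it gives no cause for the difference and no forecast for the fluoro step on any further core.

Open, going by these compounds, is whether chloro or methyl at the same place would give a similar step on the core of compound 3. Also open, on these data alone, is whether the step is tied to the trifluoromethyl group staying in place.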